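The compounds below may be only part of what the source reports. "The series", "measured", "known", "first", "only" and "open" are said of these compounds alone.

Measured so far in an ADME assay on microsomes from liver (Mus musculus) for metabolic stability; on this read-out lower numbers stand for a shorter-lived compound and higher numbers for a longer-lived compound:
- Compound 1 `COC[C@H](NC(=O)[C@H](CSC)NC(=O)c1cc(Cl)ccc1Cl)C(=O)N[C@@H](CC(C)C)C(=O)[C@@]1(C)CO1`: < 0.0834 h
- Compound 2 `COC[C@H](NC(=O)c1cc(C)on1)C(=O)N[C@@H](CSC)C(=O)N[C@@H](CC(C)C)C(=O)[C@@]1(C)CO1`: 0.202 h

Compound 1 has no exact half-life, because its only result is a limit, < 0.0834 h. It therefore stands at the limit of < 0.0834 h in this assay, at which 1 of the 2 values shown sits. Compound 2 has a measured number, 0.202 h.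

The next compound in this account, compound 3 `COC[C@H](NC(=O)[C@H](CSC)NC(=O)c1cc(C)on1)C(=O)N[C@@H](CC(C)C)C(=O)[C@@]1(C)CO1`, differs from compound 1 in one place (5-methyl-1,2-oxazol-3-yl in place of 2,5-dichlorophenyl on a carbonyl carbon). It has 5-methyl-1,2-oxazol-3-yl in place of 2,5-dichlorophenyl on a carbonyl carbon.

Among the measured compounds shown here, no two measured compounds differ in only one place, so the size of this change has not been measured directly. For the measured compounds named here, the one guide is compound 2, which carries the same 5-methyl-1,2-oxazol-3-yl group and gives 0.202 h. On that basis a modest rise in this assay is expected, although a second result at the limit remains possible. The expected change is an at least 1.7-fold higher number from compound 1 to compound 3 (0.25 log units; that floor lies within the scatter). The estimated half-life of compound 3 is 0.15 h, with an expected range from 0.07 h to 0.32 h.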

Compound 3, half-life: 0.195 h
Compound 3: the middle estimate sits 1.3-fold (0.11 log units) below what was measured; the range from low to high includes it.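

In this assay, among the compounds shown here, the compounds now give a first direct reading at this position: on a carbonyl carbon whose other neighbour is an amide-type nitrogen, 5-methyl-1,2-oxazol-3-yl in place of 2,5-dichlorophenyl gives an at least 2.3-fold higher number from compound 1 to compound 3 (0.36 log units; beyond the scatter). The position therefore responds to the group it carries, and the change lifts the half-life by more than the usual scatter of repeated measurements, with compound 3 reaching a measured 0.195 h. The step can be read only as a floor and its full size remains unknown because compound 1 has a limit rather than a number: the limit of < 0.0834 h in this assay, at which 1 of the 3 values shown sits.

The compounds shown leave open whether the rise goes with the loss of the two chlorine atoms or with the change to a five-membered aromatic ring with hetero atoms, a question that a plain phenyl group on the same carbonyl carbon would help to separate. They also leave open whether a pyridine ring or an unsubstituted 1,2-oxazol-3-yl group would give a similar half-life on the shared core.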